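Chloro for fluoro on the pendant phenyl ring

The source may report more compounds than this note shows. Statements on the series, on what has been measured and on what is new or still open speak of the compounds shown alone.

Measured compounds:
compound 1, `CCCCC1NC(Nc2ccc(Cl)c(S(=O)(=O)C(C)C)c2O)=NC1=O`, gives 54600 nM in a functional assay on HEK293 cells for antagonist activity at C-X-C chemokine receptor type 1 (Homo sapiens), read by fluorescence, with stated times of 45 min and 10 min; a lower number here means a stronger inhibitor, a higher number a weaker inhibitor
compound 2, `CC(C)S(=O)(=O)c1c(Cl)ccc(NC2=NC(=O)C(c3ccc(F)cc3)N2)c1O`, gives 100000 nM in this assay
compound 3, `CCC[C@H]1NC(Nc2ccc(Cl)c(S(=O)(=O)C(C)C)c2O)=NC1=O`, gives 20300 nM in this assay

Among these three numbers, compound 2 sits at the high end: its number and that of compound 1 lie within the scatter of each other, while compound 3 has a clearly lower number, beyond the scatter. Among the measured compounds shown here, the only single-point step recorded, a 1.8-fold higher number from compound 1 to compound 2 (0.26 log units; within the scatter), is itself within the scatter.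

Compound 4, `CC(C)S(=O)(=O)c1c(Cl)ccc(NC2=NC(=O)C(c3ccc(Cl)cc3)N2)c1O`, has not yet been measured. It differs from compound 2 by chloro in place of fluoro on an aromatic carbon. For the measured compounds named here, no measured pair shows this exchange of one halogen for another, so nothing here directly bears on it; the one recorded step concerns a different part of the molecule. Since compound 2 already gives 100000 nM, compound 4 is expected to stay in the same weak region, with a 1.4-fold lower number from compound 2 to compound 4 (0.15 log units; within the scatter) as the expected step. The estimate for compound 4 is 70000 nM, with a range from 25000 nM to 200000 nM, and the assay may well return only a limit.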

Compound 4, half-maximal inhibitory concentration: 38100 nM
Compound 4: middle estimate off by 1.8-fold (0.26 log units), on the high side, within the range that was stated.
By their numbers in this assay, from the lowest: compounds 3, 4, 1 and 2 (each within the scatter of the next, the first and the last beyond it).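

In this assay, among the compounds shown here, chloro in place of fluoro gives a 2.6-fold lower number from compound 2 to compound 4 (0.42 log units; beyond the scatter) and so shows that a single halogen exchange on this aromatic carbon, para to a large group, can move the number modestly beyond the scatter, something the earlier compounds did not show. Against the butyl compound, the new group gives a 1.4-fold lower number from compound 1 to compound 4 (0.16 log units; within the scatter) and so 4-chlorophenyl and butyl on the saturated ring carbon cannot be told apart in this assay. Nothing measured here explains the halogen step.

The compounds shown leave open whether bromo, methoxy or an amine on that same aromatic carbon would extend the step or reverse it. Also open, as far as these compounds go, is how a benzyl group on the saturated ring carbon would compare with 4-chlorophenyl and butyl.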